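This account rests on a few compounds, and the source may have more. Where it says the series, first, only, none or still open, it means among the compounds named here.

Working notes on the hydrazone series

The shared core of compound 1 `C(=N/N(Cc1ccccc1)Cc1ccccc1)\c1ccccc1` carries two benzyl groups on the hydrazone nitrogen; in an assay on liver (Sus scrofa) for inhibition of glucose-6-phosphatase catalytic subunit 1 (Homo sapiens), using microsomes (on this read-out lower numbers stand for stronger inhibition and higher numbers for weaker inhibition), compound 1 gives 1500 nM. Compound 2 `CCc1ccc(/C=N/N(Cc2ccccc2)Cc2ccccc2)o1` gives 330 nM in this assay, and compound 3 `OCc1ccc(/C=N/N(Cc2ccccc2)Cc2ccccc2)o1` gives 16000 nM. Compound 3 stands highest of the three numbers: the step of an 11-fold higher number from compound 1 to compound 3 (1.03 log units; beyond the scatter) is large, and the step of a 48-fold higher number from compound 2 to compound 3 (1.69 log units; beyond the scatter) is larger still, so the hydroxymethyl-bearing furan is the weakest point measured so far.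

Compound 4 `O=[N+]([O-])c1ccc(/C=N/N(Cc2ccccc2)Cc2ccccc2)o1` is the next member. Its change from compound 3 is nitro in place of hydroxymethyl on an aromatic carbon; the group sits next to the ring oxygen, two ring bonds from the ring atom that bears the large group. The step that bears most directly is a 48-fold higher number from compound 2 to compound 3 (1.69 log units; beyond the scatter), which shows that the hydroxy on the side chain of compound 3 coincided with a large rise in the number. The step of a 4.5-fold lower number from compound 1 to compound 2 (0.66 log units; beyond the scatter) shows that a furan without that donor can sit well below phenyl. For the measured compounds named here, no measured step contains a nitro group, so its own contribution is untested; the expectation therefore rests on the loss of hydroxymethyl only. A step of about a 27-fold lower number from compound 3 to compound 4 (1.43 log units; beyond the scatter) is expected, and compound 4 is estimated at 600 nM, within a range from 150 nM to 2500 nM.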

Compound 4, half-maximal inhibitory concentration: > 100000 nM
Compound 4 was reported as a limit; the forecaster's own chance of this, stated with the estimate: 5%; at least 160-fold (2.22 log units) between middle value and limit.
By their numbers in this assay, from the lowest: compound 2; then compound 1; then compound 3. At a limit, above all of these: compound 4.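

Compound 4 stands as a limit of the assay and not as a number: the limit of > 100000 nM in this assay, at which 1 of the 4 values shown sits. For the compounds shown here, the loss of hydroxymethyl alone does not bring the number down, since nitro at this position gives an at least 6.2-fold higher number from compound 3 to compound 4 (0.79 log units; beyond the scatter), so hydroxymethyl is not the only group on the furan that goes with a high number. Set against ethyl at the same position, nitro gives an at least 300-fold higher number from compound 2 to compound 4 (2.48 log units; beyond the scatter), and the whole 5-nitrofuran-2-yl group in place of phenyl gives an at least 66-fold higher number from compound 1 to compound 4 (1.82 log units; beyond the scatter), so a furan does not by itself sit below phenyl: of the three furans, only the ethyl one does, while the hydroxymethyl and nitro ones go against any such rule.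

The limit leaves the full size of these three steps open, and the order of hydroxymethyl and nitro rests on a single bound. Going by these compounds alone, with ethyl as the only group at this position that gives a low number, it remains open whether a methyl, a longer chain such as propyl, a methoxymethyl or an amine would sit near ethyl or near the two high compounds.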